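The compounds below may be only part of what the source reports. "The series", "measured", "known", "first", "only" and "open" are said of these compounds alone.

Working notes on the sulfonamide series.

Of the compounds shown here, two carry a number so far. Compound 1 `CCc1ccc(S(=O)(=O)Nc2ccc(-c3nc4ccccc4o3)cc2)cc1` is measured in an ADME assay on HEK293 cells (Homo sapiens) for cytotoxicity, read by resazurin assay, with a stated time of 48 h (on this read-out higher numbers stand for lower toxicity in this test and lower numbers for higher toxicity in this test), and gives 82000 nM. Compound 2 `COc1cccc(S(=O)(=O)Nc2ccc3oc(-c4ccccc4)nc3c2)c1` differs from it in more than one place and in this assay gives 63000 nM. Compound 1 thus sits at the upper of the two numbers, but the gap between compound 1 and compound 2 lies within the scatter, so the two are not separated on this read-out. Among the compounds with values here, no step between measured compounds that differ in one place is available, so nothing in the data yet shows how a single change on the sulfonyl-bearing ring moves the number.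

Compound 3 `Cc1ccc(S(=O)(=O)Nc2ccc(-c3nc4ccccc4o3)cc2)cc1` is the next to be measured in this assay. Against compound 1 the difference is hydrogen in place of methyl on a saturated chain carbon bound to an aromatic carbon. The change is small and sits on the terminal chain of the sulfonyl-bearing ring, away from the shared core. No step beyond the scatter is expected in this assay in either direction.

For compound 3 the expected value in this assay is 80000 nM, with a range from 40000 nM to 160000 nM, which means an expected step of a 1.0-fold lower number from compound 1 to compound 3 (0.01 log units; within the scatter).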

Compound 3, half-maximal cytotoxic concentration: 88000 nM
Compound 3: the middle estimate sits 1.1-fold (0.04 log units) below what was measured; the measured number falls inside the stated range.
By their numbers in this assay, from the lowest: compounds 2, 1 and 3 (each within the scatter of the next).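

Within the data shown here, this is the first step between compounds that differ in one place: with 4-methylphenyl in place of 4-ethylphenyl, this assay gives a 1.1-fold higher number from compound 1 to compound 3 (0.03 log units; within the scatter), so the two compounds are not separated on this read-out. At this position, hydrogen in place of methyl on a saturated chain carbon bound to an aromatic carbon therefore leaves the number within the scatter, a statement that holds for this one pair and does not extend to the rest of the series. No measurement is at hand that bears on why this pair behaves as it does.

Among these compounds, the single step covers only a small difference between two alkyl groups, so it does not show whether any group at this place can produce a step beyond the scatter. A longer chain such as butyl, an amine or a carboxylic acid in place of the ethyl of compound 1 would test this, and until such a comparison is available the tolerance seen here cannot be read as a general feature of this position.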